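This account rests on a few compounds, and the source may have more. Where it says the series, first, only, none or still open, it means among the compounds named here.

Values measured so far in a functional assay on ZR-75-1 cells (Homo sapiens) for inhibition, read by sulforhodamine B assay (a lower number here means a stronger inhibitor of growth, a higher number a weaker inhibitor of growth), are these:

Compound 1 `COc1cc(-c2ccc(-c3ccc(-c4nc5cc(C)ccc5[nH]4)cc3)cc2)cc(OC)c1OC` gives 190 nM
Compound 2 `FC(F)(F)c1ccc(-c2ccc(-c3ccc(-c4nc5ccccc5[nH]4)cc3)cc2)cc1` gives 48300 nM
Compound 3 `FC(F)(F)Oc1ccc(-c2ccc(-c3ccc(-c4nc5ccccc5[nH]4)cc3)cc2)cc1` gives 100000 nM

Compound 2 holds the second highest of these three numbers, far above compound 1 and below compound 3. Compound 4 `Clc1cccc(-c2ccc(-c3ccc(-c4nc5ccccc5[nH]4)cc3)cc2)c1` is not yet measured and carries 3-chlorophenyl in place of 4-(trifluoromethyl)phenyl, a change counted as 3-chlorophenyl in place of 4-(trifluoromethyl)phenyl on an aromatic carbon in full. Going by the values given here, the only measured step at this place is a 2.1-fold higher number from compound 2 to compound 3 (0.32 log units; beyond the scatter) and it is modest, but it swaps in a different group and so bears only loosely on this change. A similarly modest step in this assay is therefore expected, tentatively toward a lower number, though the direction is uncertain. The expected step is a 1.4-fold lower number from compound 2 to compound 4 (0.14 log units; within the scatter) by this estimate. For compound 4 the estimated value is 35000 nM with an expected range from 12000 nM to 100000 nM overall.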

Compound 4, concentration for 50% growth inhibition: 41200 nM
For compound 4 the middle estimate is 1.2-fold (0.07 log units) below the measured one, and the stated range covers the measured number.
By their numbers in this assay, from the lowest: compound 1; then compounds 4 and 2 (each within the scatter of the next); then compound 3.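

In this assay, 3-chlorophenyl in place of 4-(trifluoromethyl)phenyl gives a 1.2-fold lower number from compound 2 to compound 4 (0.07 log units; within the scatter). Going by these compounds alone, this is the first change here that replaces the trifluoromethyl-bearing group with a chlorine-bearing one and also moves the substituent on the ring, yet the two numbers stay within the scatter of each other. Nothing available here explains why the two compounds read alike. The compounds shown do not separate the effect of chlorine from that of its place on the ring. Going by these compounds, how an amine or a carboxylic acid on this ring would read remains open.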